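Acyl variation on the shared piperazine amide series

The source may hold more compounds than are shown below. What is called first, only, known or untested is meant among the compounds shown, and "the series" means these compounds.

Three compounds share one core and differ only in the group on the carbonyl carbon. In an assay on HEK293 cells for displacement of a labelled ligand from Melanocortin receptor 4 (Homo sapiens) (on this read-out higher numbers stand for weaker inhibition and lower numbers for stronger inhibition), compound 1 `CC(C)C[C@H](N)c1cc(C(F)(F)F)ccc1N1CCN(C(=O)COc2ccc3ccccc3c2)CC1` gives 2000 nM, compound 2 `CC(C)C[C@H](N)c1cc(C(F)(F)F)ccc1N1CCN(C(=O)[C@H](C)Cc2ccc(Cl)cc2)CC1` gives 31 nM, and compound 3 `CCOc1cccc(CC(C)C(=O)N2CCN(c3ccc(C(F)(F)F)cc3[C@@H](N)CC(C)C)CC2)c1` gives 2200 nM. Compound 3 stands at the highest number of the three; against compound 1 the difference is a 1.1-fold higher number from compound 1 to compound 3 (0.04 log units; within the scatter), while against compound 2 it is a 71-fold higher number from compound 2 to compound 3 (1.85 log units; beyond the scatter). The step of a 65-fold lower number from compound 1 to compound 2 (1.81 log units; beyond the scatter) shows the same gap from the other side.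

Compound 4 `CC(C)C[C@H](N)c1cc(C(F)(F)F)ccc1N1CCN(C(=O)CSc2ccc(Cl)cc2Cl)CC1` is the next entry. The change is ((2,4-dichlorophenyl)sulfanyl)methyl in place of 1-(3-ethoxybenzyl)ethyl on a carbonyl carbon. Going by the values given here, no measured step tests this exact exchange; the closest bearings are compound 1, where a ring joined through oxygen to the methylene gives 2000 nM, and compound 2, where a chlorine-bearing phenyl gives 31 nM. On these two points a moderate step downward is expected, a 7.3-fold lower number from compound 3 to compound 4 (0.87 log units; beyond the scatter), with wide uncertainty. Compound 4 is therefore estimated at 300 nM in this assay, within a range of 30 nM to 3000 nM.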

Compound 4, inhibition constant: 1500 nM
Compound 4: middle estimate off by 5.0-fold (0.70 log units), on the low side, within the range that was stated.
By their numbers in this assay, from the lowest: compound 2; then compounds 4, 1 and 3 (each within the scatter of the next).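

In this assay, (2,4-dichlorophenyl)sulfanyl in place of (naphthalen-2-yl)oxy on the saturated chain carbon leaves the result within the scatter (a 1.3-fold lower number from compound 1 to compound 4 (0.12 log units; within the scatter)), and the exchange against the 1-(3-ethoxybenzyl)ethyl group of compound 3 does too (a 1.5-fold lower number from compound 3 to compound 4 (0.17 log units; within the scatter)). Chlorine on the aromatic ring is therefore not sufficient for the low number of compound 2, since the dichlorophenyl group of compound 4 still lies well away from it (a 48-fold higher number from compound 2 to compound 4 (1.68 log units; beyond the scatter)). Compounds 1, 3 and 4 sit together, with compound 2 alone apart from them.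

Still open, as far as these compounds go, is whether the low number of compound 2 depends on the chlorine, the branched chain or both. A 1-benzylethyl group without chlorine and a ((4-chlorophenyl)sulfanyl)methyl group would separate these. Nothing available bears on why these steps take the sizes they do.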